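The compounds below may be only part of what the source reports. "The series", "measured", "known", "first", "only" and "open" are said of these compounds alone.

Series notes on the shared core of compound 1 `CNc1nc(NCCCN(C)C)c2sc(-c3ccc(N4CCNCC4)cc3)cc2n1`. For the measured compounds named here, in a physicochemical assay for solubility, in phosphate buffer, at pH 6.5 (on this read-out lower numbers stand for lower solubility and higher numbers for higher solubility), compound 1 gives 12.5 ug/mL, the lowest of the two numbers measured so far. Compound 2 `CNc1nc(NCCCN(C)C)c2sc(-c3cccc(C#N)c3)cc2n1`, carrying a nitrile on the aryl ring in place of the piperazin-1-yl, gives in this assay 25 ug/mL; its value and that of compound 1 lie within the scatter of each other, so the two values show no separation.

Next in line is compound 3 `CNc1nc(NCCCN(C)C)c2sc(-c3ccc(NS(C)(=O)=O)cc3)cc2n1`. Relative to compound 1 the change is methanesulfonamido in place of piperazin-1-yl on an aromatic carbon. Going by the values given here, no measured pair in the set carries this or a comparable change, so the size of the step is open. Given that compound 2 gives 25 ug/mL despite a quite different group at the same place, the step from compound 1 to compound 3 is expected to be small, a 1.0-fold lower number from compound 1 to compound 3 (0.02 log units; within the scatter), with no direction beyond the scatter to be relied upon. For compound 3 the estimate in this assay is 12 ug/mL, with a range from 4 ug/mL to 40 ug/mL.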

Compound 3, solubility: 25 ug/mL
Beside the measured number, compound 3's estimate is 2.1-fold (0.32 log units) below it; measured number inside the range.
By their numbers in this assay, from the lowest: compounds 1, 2 and 3 (each within the scatter of the next).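

In this assay, the exchange of piperazin-1-yl for methanesulfonamido on the aromatic carbon gives a 2.0-fold higher number from compound 1 to compound 3 (0.30 log units; within the scatter) and therefore no separation. For the compounds shown here, this is the first direct reading at this place: replacing a six-membered non-aromatic ring with 2 hetero atoms by an open group without a ring leaves the read-out within the scatter. No measurement in hand explains this result.

Still open, from the compounds shown here alone, is whether a carboxylic acid, a primary amine or a morpholin-4-yl group at the same aromatic carbon would give a step beyond the scatter. Also open, going by these compounds, is whether a longer chain on the sulfonamide nitrogen would keep the number in the same band as compound 1 and compound 3.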